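The source may hold more compounds than are shown below. What is called first, only, known or untested is meant among the compounds shown, and "the series" means these compounds.

For the measured compounds named here, in a functional assay on MDA-MB-231 cells (Homo sapiens) for antiproliferative activity, with a stated time of 4 days (a lower number here means a stronger inhibitor, a higher number a weaker inhibitor), compound 1 (`COc1ccc(-c2[nH]c3cc(OC)ccc3c2C=O)cc1`) gives 35 nM and compound 2 (`COc1ccc(-c2[nH]c3cc(Cl)ccc3c2C=O)cc1`) gives 27 nM, so compound 2 stands within the scatter of the only other measured number. The next analogue is compound 3 (`Cc1ccc(-c2[nH]c3cc(Cl)ccc3c2C=O)cc1`): methyl in place of methoxy on an aromatic carbon. In words, this is methyl in place of methoxy on an aromatic carbon of a six-membered aromatic ring of carbon only, para to a large group.

Going by the values given here, only one measured step bears on this, a 1.3-fold lower number from compound 1 to compound 2 (0.11 log units; within the scatter), in which chloro took the place of methoxy on an aromatic carbon, and it stayed within the scatter. That swap lies at a different place in the structure, so it is only a loose guide. Both measured compounds carry the methoxy that is replaced here, and no measurement tests this change directly. A small step is therefore expected in this assay, leaning towards a higher number and possibly not beyond the scatter. The expected step is a 1.9-fold higher number from compound 2 to compound 3 (0.27 log units; within the scatter). Compound 3 is estimated at 50 nM, with an expected range from 15 nM to 200 nM.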

Compound 3, half-maximal inhibitory concentration: 7.8 nM
Compound 3: middle estimate off by 6.4-fold (0.81 log units), on the high side; measured number below the stated range.
By their numbers in this assay, from the lowest: compound 3; then compounds 2 and 1 (each within the scatter of the next).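

In this assay, for the compounds shown here, replacing methoxy with methyl on an aromatic carbon para to a large group gives a 3.5-fold lower number from compound 2 to compound 3 (0.54 log units; beyond the scatter), the only step so far that lies beyond the scatter. Going by these compounds alone, the earlier step, a 1.3-fold lower number from compound 1 to compound 2 (0.11 log units; within the scatter), was made at a different place and stayed within the scatter, so this result is the first sign that the series responds to a change in structure in this assay, and that the position para to a large group is where it does so. It also shows that the methoxy oxygen, with its hydrogen-bond acceptor, is not needed for a low number here, although no measurement available explains why the number falls.

With only methoxy and methyl shown at this position, it remains open whether the lower number follows from the presence of methyl or from the absence of methoxy, and ethyl, trifluoromethyl, chloro or a plain hydrogen there would help to separate the two. Also open, as far as these compounds go, is whether the gain holds when the aldehyde of the shared core gives way to a nitrile or a carboxylic acid.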